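Notes on the cyclobutyloxy-to-methyl change

The source may report more compounds than this note shows. Statements on the series, on what has been measured and on what is new or still open speak of the compounds shown alone.

Within the data shown here, compound 2 `Cc1nc(C)n(CC(=O)N2CCN(c3sc(C(F)(F)F)nc3-c3cnc(OC4CCC4)nc3)C[C@H]2C)n1` gives 4 nM in a functional assay on CHO-K1 cells for antagonist activity at C-X-C chemokine receptor type 3 (Homo sapiens), read by FLIPR, with a stated time of 10 min (a lower number here means a stronger inhibitor, a higher number a weaker inhibitor), the lowest of the two numbers so far; compound 1 `COc1ncc(-c2nc(C(F)(F)F)sc2N2CCN(C(=O)Cn3nc(C)nc3C)[C@H](C)C2)cn1` gives 25 nM in this assay. Among the measured compounds shown here, the single measured step, a 6.3-fold lower number from compound 1 to compound 2 (0.80 log units; beyond the scatter), is the only guide for the series. Compound 3 `Cc1ncc(-c2nc(C(F)(F)F)sc2N2CCN(C(=O)Cn3nc(C)nc3C)[C@H](C)C2)cn1` differs from compound 2 by methyl in place of cyclobutyloxy on an aromatic carbon. For the measured compounds named here, this strips the whole cyclobutyloxy rather than shortening it back to methoxy, so no measured pair covers it exactly; the nearest evidence is the gain seen on going from methoxy to cyclobutyloxy, and the change also removes the one hydrogen-bond acceptor counted in the leaving group. A loss beyond the scatter in this assay is expected, about the size of that step or somewhat more. Compound 3 is therefore expected to give 40 nM, within 10 nM to 160 nM. The expected step is a 10-fold higher number from compound 2 to compound 3 (1.00 log units; beyond the scatter).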

Compound 3, half-maximal inhibitory concentration: 19 nM
For compound 3 the middle estimate is 2.1-fold (0.32 log units) above the measured one; the range from low to high includes it.
By their numbers in this assay, from the lowest: compound 2; then compounds 3 and 1 (each within the scatter of the next).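

In this assay, replacing cyclobutyloxy with methyl on this aromatic carbon gives a 4.8-fold higher number from compound 2 to compound 3 (0.68 log units; beyond the scatter), so the advantage of compound 2 does not carry over to a one-carbon group. Methyl and methoxy are not separated at this place, with a 1.3-fold lower number from compound 1 to compound 3 (0.12 log units; within the scatter), so among these three compounds only cyclobutyloxy stands apart, and the oxygen alone brings no readable change when the group on it is methyl. No measurement on hand accounts for either step.

The compounds shown leave open whether the gain needs the four-membered ring or only more carbon on the oxygen, a question that isopropoxy, cyclopropyloxy or a straight butoxy chain at this position would address. They also leave open whether the oxygen is needed at all once the group is larger, as a cyclobutyl attached directly or a cyclobutylamino group would show.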